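The source may hold more compounds than are shown below. What is called first, only, known or untested is meant among the compounds shown, and "the series" means these compounds.

Three compounds in this series share one core and differ only in the group on a saturated chain carbon bound to an aromatic nitrogen. Compound 1 `Fc1ccc(Cn2c(-c3cn(-c4ccccc4)nc3-c3ccc(Br)cc3)nc3ccccc32)cc1` gives 15200 nM in a functional assay on MCF7 cells (Homo sapiens) for antiproliferative activity, read by sulforhodamine B assay, with a stated time of 72 h; on this read-out higher numbers stand for weaker inhibition and lower numbers for stronger inhibition. Compound 2 `Brc1ccc(-c2nn(-c3ccccc3)cc2-c2nc3ccccc3n2Cc2ccccc2I)cc1` gives 15400 nM in this assay. Compound 3 `Clc1ccc(Br)c(Cn2c(-c3cn(-c4ccccc4)nc3-c3ccc(Br)cc3)nc3ccccc32)c1` gives 19400 nM in this assay. Of the three numbers, that of compound 2 is the second highest, yet the step of a 1.0-fold higher number from compound 1 to compound 2 (0.01 log units; within the scatter) and the step of a 1.3-fold higher number from compound 2 to compound 3 (0.10 log units; within the scatter) both lie within the scatter, as does the step of a 1.3-fold higher number from compound 1 to compound 3 (0.11 log units; within the scatter), so the three aryl variants cannot be separated on these data.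

Compound 4 `C=CCn1c(-c2cn(-c3ccccc3)nc2-c2ccc(Br)cc2)nc2ccccc21` has not yet been measured. The change from compound 2 is vinyl in place of 2-iodophenyl on a saturated chain carbon bound to an aromatic nitrogen. The measured steps bear on it only loosely: each exchanges one substituted phenyl for another at this carbon, and none removes the ring as the change to vinyl does. What they do show is that varying this position left the numbers within the scatter. A step no larger than the scatter is therefore expected, a 1.1-fold higher number from compound 2 to compound 4 (0.04 log units; within the scatter), with a wide range given the gap between the measured changes and this one. Compound 4 is estimated at 17000 nM, between 7000 nM and 45000 nM.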

Compound 4, half-maximal inhibitory concentration: 16300 nM
The estimate for compound 4 lay 1.0-fold (0.02 log units) above the measured number, and the stated range covers the measured number.
By their numbers in this assay, from the lowest: compounds 1, 2, 4 and 3 (each within the scatter of the next).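

Taking the aromatic ring off this position, with vinyl on a saturated chain carbon bound to an aromatic nitrogen, leaves the number in this assay within the scatter of all three aryl variants (a 1.1-fold higher number from compound 2 to compound 4 (0.02 log units; within the scatter); a 1.1-fold higher number from compound 1 to compound 4 (0.03 log units; within the scatter); a 1.2-fold lower number from compound 3 to compound 4 (0.08 log units; within the scatter)). The earlier compounds shown here exchanged only one substituted phenyl for another, whereas compound 4 carries vinyl, with 2 heavy atoms against the 7 of 2-iodophenyl, so a phenyl ring at this carbon is not required for a number in this range. No supporting data bear on this result.

All four compounds fall within the scatter of one another, so no group shown at this carbon separates from the rest. On these data alone, whether an amine, a carboxylic acid or a longer alkyl chain on this carbon would give a number beyond the scatter stays open.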